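From carbamoyl to trifluoromethyl: compound 2 to compound 3

The compounds below may be only part of what the source reports. "The series", "measured", "known", "first", "only" and "open" are said of these compounds alone.

Of the compounds shown here, two sharing one core have been read in an ADME assay on Raji cells (Homo sapiens) for cytotoxicity, with a stated time of 72 h; a lower number here means that less compound is needed, a higher number that more compound is needed for the effect: compound 1 `Cc1cc(NC(=O)Nc2ccccc2C(C)(C)C)c2ccccc2n1` and compound 2 `Cc1cc(NC(=O)Nc2ccccc2C(N)=O)c2ccccc2n1`. Compound 1 gives > 25000 nM, which is a limit of the assay and not a number. Compound 2 gives > 25000 nM, which is likewise a limit and not a number. Compound 2 therefore has no numeric position in the series. The only measured move is a step that the two limits leave unreadable from compound 1 to compound 2, which sets neither a size nor a direction for the next change. What the series shows so far is the limit of > 25000 nM in this assay, at which 2 of the 2 values shown sit.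

Compound 3 `Cc1cc(NC(=O)Nc2ccccc2C(F)(F)F)c2ccccc2n1` carries trifluoromethyl in place of carbamoyl on an aromatic carbon. Tert-butyl in compound 1 and carbamoyl in compound 2 both end at the same limit, so compound 3 is expected to end there too, with no step beyond the scatter and no favoured direction in this assay. The expected size is a number no higher from compound 2 to compound 3 (the limit leaves the size open), though the assay will most likely report a limit again. For compound 3 the estimate is 25000 nM, with an expected range of 12000 nM to 50000 nM.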

Compound 3, half-maximal effective concentration: > 25000 nM
Compound 3: a limit, no number; the forecaster's own chance of this, stated with the estimate: 85%; the middle value sits exactly at the limit.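

In this assay compound 3 gives > 25000 nM, which is a limit of the assay and not a number. No step can be read among compound 1, compound 2 and compound 3, since their limits fix neither size nor direction. The compounds shown leave open whether any change at this aromatic carbon shifts the read-out, with the series resting on one value: the limit of > 25000 nM in this assay, at which 3 of the 3 values shown sit.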